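The compounds below may be only part of what the source reports. "The series", "measured", "known", "first", "only" and "open" are said of these compounds alone.

Measured compounds:
compound 1 `CC(=O)N1CCC(n2cc(-c3cnc(N)c4oc(-c5cccc6nnsc56)cc34)cn2)CC1` — 0.68
compound 2 `CC(=O)N1CCC(n2cc(-c3cnc(N)c4oc(-c5csc6cnccc56)cc34)cn2)CC1` — 0.68

Compound 1 and compound 2 share the same core and differ only in the fused bicyclic group attached to it. In an ADME assay on microsomes from liver (Homo sapiens) for metabolic stability (a lower number here means that the liver removes a smaller share, a higher number that the liver removes a larger share of the compound in one pass), compound 1 gives 0.68. In this assay compound 2 gives 0.68. For the measured compounds named here, the one measured step, no change at the digits printed from compound 1 to compound 2 (within the scatter), shows that exchanging one fused bicyclic group for another left the read-out level within the scatter. Going by the values given here, compound 1 therefore stands level with compound 2, its only neighbour, on the numbers in hand.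

Compound 3 `CC(=O)N1CCC(n2cc(-c3cnc(N)c4oc(-c5cccc6cnsc56)cc34)cn2)CC1` is not yet measured. It differs from compound 1 by a group of 9 heavy atoms (7 carbon, 1 nitrogen, 1 sulfur; one five-membered aromatic ring with 2 hetero atoms, one six-membered aromatic ring of carbon only) in place of a group of 9 heavy atoms (6 carbon, 2 nitrogen, 1 sulfur; one five-membered aromatic ring with 3 hetero atoms, one six-membered aromatic ring of carbon only), on an aromatic carbon. Among the compounds with values here, the only step that bears on this change is the one from compound 1 to compound 2, no change at the digits printed from compound 1 to compound 2 (within the scatter), where a comparable exchange of a fused bicyclic group produced no step beyond the scatter. On that basis the step from compound 1 to compound 3 is expected to be no change at the digits printed from compound 1 to compound 3 (within the scatter), that is, no change beyond the scatter. Compound 3 is accordingly estimated to give 0.68, with a range from 0.55 to 0.8.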

Compound 3, hepatic extraction ratio: 0.73
Beside the measured number, compound 3's estimate is 0.050 below it; measured number inside the range.
By their numbers in this assay, from the lowest: compounds 1, 2 and 3 (each within the scatter of the next).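

In this assay, the group with two hetero atoms in its five-membered ring, entering in place of the one with three, gives a number 0.050 higher from compound 1 to compound 3 (within the scatter), and in place of the group with a hetero atom in each ring it gives a number 0.050 higher from compound 2 to compound 3 (within the scatter). For these three compounds, then, on an aromatic carbon of a five-membered aromatic ring with 1 oxygen, next to the ring oxygen, neither the number of hetero atoms in the fused group nor the ring that carries them, nor the change from 3 to 2 hydrogen-bond acceptors, moves the hepatic extraction ratio beyond the scatter. No supporting measurement bears on why these fused groups stand so close together.

On these data alone, all three groups are fused aromatic pairs of 9 heavy atoms containing sulfur, so it remains open whether a group of a different kind at this place, such as a single phenyl ring, a morpholine or a primary amine, would step beyond the scatter. The compounds also share everything outside this position, which leaves open whether the same level would hold if the rest of the molecule were changed.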